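The compounds below may be only part of what the source reports. "The series", "measured", "known", "first", "only" and "open" are said of these compounds alone.

Of the compounds shown here, two with a shared core have been tested so far. Compound 1 `CC(C)(C)c1ccc(C(=O)NN2C(=O)NC3(CC3(C)C)C2=O)cc1` gives 100 mg/kg in a functional assay on the whole organism for inhibition, with Mus musculus as the target, with a stated time of 0.5 h; a higher number here means that more compound is needed for the effect, a lower number that less compound is needed. Among the measured compounds shown here, compound 2 `CC1(C)CC12NC(=O)N(NC(=O)c1ccc(F)cc1)C2=O` gives 300 mg/kg in this assay, the higher of the two numbers recorded; the only measured step, a 3.0-fold higher number from compound 1 to compound 2 (0.48 log units; beyond the scatter), separates it from compound 1.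

Compound 3 `CC1(C)CC12NC(=O)N(NC(=O)c1ccc(C(F)(F)F)cc1)C2=O` is not yet measured. Its difference from compound 2 is trifluoromethyl in place of fluoro on an aromatic carbon.

For the measured compounds named here, the one step that bears on this is the change from compound 1 to compound 2, where a 3.0-fold higher number from compound 1 to compound 2 (0.48 log units; beyond the scatter). Compound 3 moves partway back from the fluoro toward a group of more heavy atoms, and the trifluoromethyl enters with 4 heavy atoms where the fluoro had 1, so a modest lowering of the number is expected, though the direction rests on a single step. For compound 3 the expected step is a 1.5-fold lower number from compound 2 to compound 3 (0.18 log units; within the scatter). Compound 3 is therefore estimated at 200 mg/kg, within a range from 100 mg/kg to 400 mg/kg.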

Compound 3, minimum effective dose: 300 mg/kg
Compound 3: middle estimate off by 1.5-fold (0.18 log units), on the low side; the measured number falls inside the stated range.
By their numbers in this assay, from the lowest: compound 1; then compounds 2 and 3 (each within the scatter of the next).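

In this assay, putting trifluoromethyl in place of fluoro at this position, para to a large group, gives no change at the digits printed from compound 2 to compound 3 (within the scatter). Adding heavy atoms here therefore does not by itself change the number, at least between these two groups. Trifluoromethyl in place of tert-butyl gives a 3.0-fold higher number from compound 1 to compound 3 (0.48 log units; beyond the scatter), so among these three compounds only the tert-butyl compound stands apart, with the lower number and thus less compound needed for the effect.

From the compounds shown here alone, whether an amine, a carboxylic acid or a longer chain at this position would shift the number in either direction remains open. Nothing available explains why tert-butyl differs from the two fluorine-containing groups.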